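This account rests on a few compounds, and the source may have more. Where it says the series, first, only, none or still open, it means among the compounds named here.

Measured compounds in an ADME assay on Huh-7 cells (Homo sapiens) for cytotoxicity, with a stated time of 72 h; a lower number here means that less compound is tolerated, a higher number that more compound is tolerated:
Compound 1 `CC(C)CCN1C(=O)C(C2=NS(=O)(=O)c3cc(NS(C)(=O)=O)ccc3N2)=C(O)C2CCCC21` gives > 1000 nM, which is a limit of the assay and not a number.
Compound 2 `CN1C(=O)C(C2=NS(=O)(=O)c3cc(NS(C)(=O)=O)ccc3N2)=C(O)C2CCCC21` carries "not determined" (no result reported).
Compound 3 `CS(=O)(=O)Nc1ccc2c(c1)S(=O)(=O)N=C(C1=C(O)C3CCCC3N(Cc3ccc(Cl)cc3)C1=O)N2` gives > 10000 nM, again only a limit of the assay.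

Compound 3 therefore stands at a limit in this assay, as does compound 1, while compound 2 has no result at all; none of the three is placed on a definite value. For the measured compounds named here, the only step that joins two measured compounds, a step that the two limits leave unreadable from compound 1 to compound 3, cannot be read, since its two ends sit at the limit of > 1000 nM in this assay, at which 1 of the 3 values shown sits, and (the limit of > 10000 nM in this assay, at which 1 of the 3 values shown sits).

Compound 4 `CS(=O)(=O)Nc1ccc2c(c1)S(=O)(=O)N=C(C1=C(O)C3CCCC3N(Cc3cccc(F)c3)C1=O)N2` differs from compound 3 by 3-fluorophenyl in place of 4-chlorophenyl on a saturated chain carbon bound to an amide-type nitrogen in a ring. Going by the values given here, the one measured step touches the same place but yields no size, so no measured step gives a direction or magnitude for this exchange. Compound 4 is accordingly expected to stay near the limit where compound 3 sits, most likely again reported as a limit. The step from compound 3 to compound 4 in this assay is expected to be about a step that the limit leaves unreadable from compound 3 to compound 4. Compound 4 is estimated at 15000 nM, with a range from 4000 nM to 60000 nM.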

Compound 4, half-maximal cytotoxic concentration: > 33000 nM
Compound 4 was reported as a limit; the forecaster's own chance of this, stated with the estimate: 75%; middle value at least 2.2-fold (0.34 log units) away from the limit.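

In this assay compound 1, compound 3 and compound 4 are each reported only as a limit, so the steps from compound 3 to compound 4 and from compound 1 to compound 4 cannot be read. The compounds shown leave open what cytotoxic concentration any of the three actually reaches, and whether exchanging the group at this place changes it at all.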